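The source may report more compounds than this note shows. Statements on the series, on what has been measured and on what is new or still open speak of the compounds shown alone.

Among the compounds with values here, compound 1 `O=C(CCSc1nc2ccccc2o1)N1CCCC1` is the one member of this small set with a result in hand: in an ADME assay on microsomes from liver (Mus musculus) for metabolic stability, read by LC-MS, using NADPH, with a stated time of 45 min, tested at 0.5 uM (on this read-out higher numbers stand for fast clearance and lower numbers for slow clearance), compound 1 gives 161 mL/min/g, a number that sits toward the fast-clearance end of this read-out. Compound 2 `Cc1ccc2oc(SCCC(=O)N3CCCC3)nc2c1` carries a methyl on the shared core; in this assay compound 2 stands as "not determined" (no result reported), with no result reported, so there is no single number on which to place it beside compound 1. Compound 3 `O=C(CCSc1nc2cc(F)ccc2o1)N1CCCC1` differs from compound 2 by fluoro in place of methyl on an aromatic carbon. Within the data shown here, no measured pair of this kind exists among the compounds, so the size of the step from compound 2 to compound 3 cannot be read from any result; the expectation is that it stays within the usual scatter of this assay, with no firm direction. The only anchor for a forecast is compound 1, whose value of 161 mL/min/g belongs to a close relative of both compound 2 and compound 3. On that footing compound 3 is expected to give about 130 mL/min/g in this assay, with a likely range from 60 mL/min/g to 260 mL/min/g.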

Compound 3, intrinsic clearance in a liver preparation (reported as CLH), per the amount of preparation that the assay uses: 115 mL/min/g
Beside the measured number, compound 3's estimate is 1.1-fold (0.05 log units) above it; measured number inside the range.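

Within this assay the swap of fluoro for hydrogen on an aromatic carbon of the shared core gives a 1.4-fold lower number from compound 1 to compound 3 (0.15 log units; within the scatter) and this is the one measured change at this position so far. A step of this size cannot be told apart from what repeat measurements of the same compound would give, so this swap does not separate compound 3 from compound 1 on this read-out, and the position can carry a fluoro without a clear shift in the number. No measurement shown here offers an explanation for the result.

Within the data shown here, the step between compound 2 and compound 3 cannot be read, and neither can the one between compound 1 and compound 2, since compound 2 has no number, so what a methyl does at this position remains unknown. Also open, as far as these compounds go, is whether a larger group on the same aromatic carbon, such as chloro, methoxy or an amine, would move the number by more than the usual scatter, as one small fluoro does not.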